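Swapping the diazepane for an aminopiperidine on a stable compound

The source may report more compounds than this note shows. Statements on the series, on what has been measured and on what is new or still open speak of the compounds shown alone.

Measured in an ADME assay on microsomes from intestine (Rattus norvegicus) for metabolic stability, with NADPH named in the record, with a stated time of 60 min, in the absence of a further agent; on this read-out lower numbers stand for a less stable compound and higher numbers for a more stable compound:
- Compound 1 `Cc1cncc(-c2cnc3cnn(-c4cccc(N5CCCNCC5)n4)c3c2)n1`: 87%
- Compound 2 `c1cncc(-c2cc3c(-c4cccc(N5CCCNCC5)n4)n[nH]c3cn2)c1`: "stable" (no number reported)

In this assay, compound 2 stands without a single number. Its record reads "stable" (no number reported), so it cannot be placed numerically against compound 1, which gives 87%.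

The next structure is compound 3 `N[C@H]1CCCN(c2cccc(-c3n[nH]c4cnc(-c5cccnc5)cc34)n2)C1`, which has the same atoms as compound 2, joined differently. The change is 3-aminopiperidin-1-yl in place of 1,4-diazepan-1-yl on an aromatic carbon. It places 3-aminopiperidin-1-yl in place of 1,4-diazepan-1-yl on an aromatic carbon, next to the ring nitrogen.

Going by the values given here, no measured pair shows a step of this kind, so the size of the change remains open. With compound 1 at 87%, a step no larger than the usual scatter is expected, in neither direction.

For compound 3 the expected value is 84%, with an estimated range of 66% to 97%.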

Compound 3, percent of the compound remaining: 93%
Estimate against measurement, compound 3: 9 percentage points below; the range from low to high includes it.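

In this assay, going by these compounds alone, compound 3 gives 93% while compound 2 has only the record "stable" (no number reported) and so no step from compound 2 to compound 3 can be read. The compounds shown leave open how 3-aminopiperidin-1-yl in place of 1,4-diazepan-1-yl changes stability. No evidence here bears on this result.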